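The source may hold more compounds than are shown below. What is called first, only, known or untested is meant among the compounds shown, and "the series" means these compounds.

Measured so far in a functional assay on A2780 cells (Homo sapiens) for cytotoxicity, read by MTT assay, with a stated time of 72 h; on this read-out lower numbers stand for stronger inhibition and higher numbers for weaker inhibition:
compound 1, `Cc1cc(C)cc(CNC(=O)CN(CCCCCC(=O)Nc2ccccc2N)C(=O)c2cc(C)cc(C)c2)c1`, 5100 nM
compound 2, `Nc1ccccc1NC(=O)CCCCCN(CC(=O)NCc1ccccc1)C(=O)c1cccc2ccccc12`, 22800 nM
compound 3, `Cc1cc(C)cc(C(=O)N(CCCCCC(=O)Nc2cc(-c3ccccc3)ccc2N)CC(=O)NCc2ccccc2)c1`, 17100 nM

Among these three numbers compound 1 stands lowest. Compound 3 gives the nearest value, and compound 2 the furthest; both gaps from compound 1 lie beyond the usual scatter, so compound 1 is the most potent of the three in this assay.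

Compound 4, `COc1ccc(CNC(=O)CN(CCCCCC(=O)Nc2ccccc2N)C(=O)c2cc(C)cc(C)c2)cc1`, is not yet measured. It differs from compound 1 in one place: 4-methoxyphenyl in place of 3,5-dimethylphenyl on a saturated chain carbon bound to an amide-type nitrogen. Going by the values given here, no pair of measured compounds differs in only this way, so nothing measured speaks directly to the change. The step from compound 1 to compound 4 is expected to be small, a 1.4-fold higher number from compound 1 to compound 4 (0.14 log units; within the scatter), tending toward a slightly higher number but possibly not beyond the scatter. Compound 4 is therefore estimated at 7000 nM, within a range of 2500 nM to 20000 nM.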

Compound 4, half-maximal inhibitory concentration: 24600 nM
For compound 4 the middle estimate is 3.5-fold (0.55 log units) below the measured one, outside the stated range (above it).
By their numbers in this assay, from the lowest: compound 1; then compounds 3, 2 and 4 (each within the scatter of the next).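

In this assay, 4-methoxyphenyl in place of 3,5-dimethylphenyl on a saturated chain carbon bound to an amide-type nitrogen gives a 4.8-fold higher number from compound 1 to compound 4 (0.68 log units; beyond the scatter), beyond the scatter. Going by these compounds alone, this is the first single-place step available, and it shows that this position does respond to a change of the aromatic group, here toward weaker inhibition. Nothing available explains the step.

The compounds shown cannot separate the removal of the two methyl groups from the arrival of the methoxy group, since both happen in one step. They also leave open how a pyridylmethyl group would read in this place.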